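This account rests on a few compounds, and the source may have more. Where it says the series, first, only, none or still open, it means among the compounds named here.

In a functional assay (aorta) with Rattus norvegicus as the target (a higher number here means that more compound is needed for the effect, a lower number that less compound is needed), three compounds on a shared core have been measured. Compound 1 (`COc1ccc(-c2nc(CNC(C)=O)sc2-c2ccc(OC)cc2)cc1`) gives 8.1 uM and compound 2 (`COc1ccc(-c2nc(CNC(=O)c3cccnc3)sc2-c2ccc(OC)cc2)cc1`) gives 8.2 uM there, while compound 3 (`CCN(CC)C(=O)c1nc(-c2ccc(OC)cc2)c(-c2ccc(OC)cc2)s1`) gives 14 uM and so stands level with both within the scatter. The next compound, compound 4 (`COc1ccc(-c2nc(CCC(=O)O)sc2-c2ccc(OC)cc2)cc1`), has 2-carboxyethyl in place of diethylcarbamoyl on an aromatic carbon. Going by the values given here, three measured steps bear on this change. Replacing the group at this same place gave a 1.7-fold higher number from compound 1 to compound 3 (0.24 log units; within the scatter) and a 1.7-fold higher number from compound 2 to compound 3 (0.23 log units; within the scatter) in turn, while pyridin-3-yl in place of methyl on a carbonyl carbon gave a 1.0-fold higher number from compound 1 to compound 2 (0.01 log units; within the scatter) and all three lie within the scatter. Among the compounds with values here, no measured compound carries 2-carboxyethyl, so the direction remains open and no shift beyond the scatter is expected in this assay for this change. The expected change is a 1.3-fold lower number from compound 3 to compound 4 (0.10 log units; within the scatter) and it is an estimate only. Compound 4 is expected at 11 uM with an estimated range from 4 uM to 30 uM as the likely span.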

Compound 4, concentration for half-maximal effect: > 100 uM
Compound 4 ended at the assay's limit; the forecaster's own chance of this, stated with the estimate: 10%; middle value at least 9.0-fold (0.95 log units) away from the limit.
By their numbers in this assay, from the lowest: compounds 1, 2 and 3 (each within the scatter of the next). At a limit, above all of these: compound 4.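

Compound 4 stands at a limit of this assay, not at a number: the limit of > 100 uM in this assay, at which 1 of the 4 values shown sits.

The three groups in compounds 1, 2 and 3 had left the number within the scatter, so this place on the aromatic carbon had shown no response to the change of group; 2-carboxyethyl is the only one of the four groups that moves it beyond the scatter. Putting 2-carboxyethyl in place of diethylcarbamoyl gave an at least 7.1-fold higher number from compound 3 to compound 4 (0.85 log units; beyond the scatter), and the changes on the saturated chain carbon gave an at least 12-fold higher number from compound 2 to compound 4 (1.08 log units; beyond the scatter) and an at least 12-fold higher number from compound 1 to compound 4 (1.09 log units; beyond the scatter).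

The compounds shown do not separate the carboxylic acid from the chain that carries it, which a methyl ester or a primary amide on the same chain, or a carboxymethyl group, could do. Nor do they show whether an amine on that chain would stay level with compounds 1, 2 and 3.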